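This account rests on a few compounds, and the source may have more. Where it says the series, first, only, none or still open, it means among the compounds named here.

Within the data shown here, in a functional assay on PC-3 cells (Homo sapiens) for inhibition, read by MTT assay, with a stated time of 48 h (a higher number here means a weaker inhibitor, a lower number a stronger inhibitor), compound 1 (`COc1ccc(CN(c2cc(OC)c(OC)c(OC)c2)S(=O)(=O)c2ccc(C)cc2)cc1`) gives 8220 nM and holds the lower of the two numbers so far. The other number belongs to compound 2 (`COc1ccc(CN(c2cc(OC)c(OC)c(OC)c2)S(=O)(=O)c2ccc(OC)c(OC)c2)cc1`) at 20100 nM and is beyond the scatter from the first. Compound 3 (`COc1cc(N(Cc2ccc(F)cc2)S(=O)(=O)c2ccc(C)cc2)cc(OC)c1OC`) keeps the 4-methylphenyl on the sulfonyl sulfur and differs from compound 1 elsewhere (fluoro in place of methoxy on an aromatic carbon) with 4-fluorobenzyl in place of 4-methoxybenzyl. Among the measured compounds shown here, the only measured step is a 2.4-fold higher number from compound 1 to compound 2 (0.39 log units; beyond the scatter) and it is modest, but it was made on the sulfonyl sulfur, so it bears only loosely on this change. For the measured compounds named here, no measured step covers the swap of methoxy for fluoro, and no shift beyond the scatter is expected in either direction. The expected step is a 1.1-fold higher number from compound 1 to compound 3 (0.04 log units; within the scatter) and stays an estimate. Compound 3 is estimated at 9000 nM with an expected range from 3500 nM to 23000 nM for now.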

Compound 3, half-maximal inhibitory concentration: 20700 nM
Estimate against measurement, compound 3: 2.3-fold (0.36 log units) below; the measured number falls inside the stated range.
By their numbers in this assay, from the lowest: compound 1; then compounds 2 and 3 (each within the scatter of the next).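

In this assay, the 4-methoxybenzyl group, which stayed the same in the earlier pair, proves not to be indifferent to change: fluoro in place of methoxy on its aromatic carbon gives a 2.5-fold higher number from compound 1 to compound 3 (0.40 log units; beyond the scatter). With the 4-methylphenyl on the sulfonyl sulfur held constant, the methoxy therefore goes with the lower number, although the step is only modest. Nothing available explains why this swap raises the number.

Going by these compounds, it remains open whether a hydroxyl group, an amine or a longer chain such as ethoxy at this place would match compound 1 or improve on it. On these data alone, it is also open whether the swap of methoxy for fluoro would give a similar step with 3,4-dimethoxyphenyl on the sulfonyl sulfur.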